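The source may report more compounds than this note shows. Statements on the series, on what has been measured and on what is new or still open speak of the compounds shown alone.

Measured in a functional assay on the whole organism (strain Kunming) with Mus musculus as the target, with a stated time of 0.5 h, at a dose of 100 mg/kg by the intraperitoneal route; a higher number here means a weaker effect of the compound at the dose given, a lower number a stronger effect:
compound 1 `COc1cc(OC)c(OC)cc1/C=C/COC(=O)/C=C/c1c(OC)ccc(OC)c1OC` gives 100%
compound 2 `COc1cc(OC)c(OC)cc1/C=C/COC(=O)/C=C/c1ccc(Br)cc1` gives 100%
compound 3 `COc1cc(OC)c(OC)cc1/C=C/COC(=O)/C=C/c1ccc(OC)c(OC)c1OC` gives 100%

Compound 2 stands level with compound 1 and compound 3 at the digits shown. Its nearest neighbour is compound 1, with no change at the digits shown, within the scatter; its furthest is compound 3, again with no change at the digits shown, within the scatter. For the measured compounds named here, no single-point step between the measured compounds is given, and the three readings in this assay describe one flat level with nothing beyond the scatter among them. Whether the aromatic end carries three methoxy groups in either arrangement or a single bromo, the read-out is the same.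

Compound 4 `COc1cc(OC)c(OC)cc1/C=C/COC(=O)/C=C/c1ccc(F)cc1` has not yet been measured in this assay. It differs from compound 2 in one place: fluoro in place of bromo on an aromatic carbon. Fluoro in place of bromo on an aromatic carbon, para to a large group, is a small change within a series that so far shows no movement at all.

Because compound 2 reads 100% and compound 1 and compound 3 sit at the same level, the step from compound 2 to compound 4 is expected to be no change at the digits printed from compound 2 to compound 4 (within the scatter), none beyond the scatter. Compound 4 is therefore estimated at 100%, with a range of 85% to 100%.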

Compound 4, a percentage reported as activity, at one dose (the size of the read-out at that dose, not a potency): 100%
Compound 4: the middle estimate sits on the measured number at the digits printed, and the stated range covers the measured number.
By their numbers in this assay, from the lowest: compounds 1, 2, 3 and 4 (each within the scatter of the next).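

For the compounds shown here, exchanging bromo for fluoro on an aromatic carbon, para to a large group, gives no change at the digits printed from compound 2 to compound 4 (within the scatter) in this assay, and this is the first step that changes one place only. The earlier compounds shown here showed one flat level across different aromatic ends, but none of them isolated a single substituent, whereas this pair shows that the read-out does not separate these two halogens at this position. Going by these compounds alone, nothing measured here accounts for the lack of movement, and the result describes only this pair at the one dose and time tested.

As far as these compounds go, whether this position can move the read-out at all remains open, as an amine, a carboxylic acid or a nitrile in place of the halogen would test a different kind of group from the two halogens compared here. Also open, from the compounds shown here alone, is whether the level changes when the change lies elsewhere in the molecule, for example an amide in place of the ester link or a longer chain between the shared core and the ester.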